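A few compounds are considered here, and "the series" means these few. Any claim that something is new, unique, unknown or untested is made for them only; others in the source may bear on it.

Measured compounds in an assay on isolated protein for displacement of a labelled ligand from metabotropic glutamate receptor 5 (Homo sapiens), with a stated time of 60 min, tested at 1 uM; on this read-out higher numbers stand for more inhibition at the one concentration tested (going by the name of the read-out) and lower numbers for less inhibition:
- compound 1, `Cc1ccc(S(=O)(=O)c2cnc3ccc(Cl)cc3c2N2CCC(C)CC2)cc1`: 95%
- compound 2, `Cc1ccc(S(=O)(=O)c2cnc3ccc(Cl)cc3c2N2CCC(C)CC2)cc1C`: 84%
- compound 3, `Cc1ccc2ncc(S(=O)(=O)c3ccc(F)cc3)c(N3CCC(C)CC3)c2c1`: 90%

Compound 2 gives the lowest of the three numbers, but its gap to compound 3 lies within the scatter, so no order between compound 2 and compound 3 can be read. For the measured compounds named here, the only step that is beyond the scatter is a number 11 percentage points lower from compound 1 to compound 2 (beyond the scatter), the change there being methyl in place of hydrogen on an aromatic carbon.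

Compound 4, `CC1CCN(c2c(S(=O)(=O)c3cccc(C#N)c3)cnc3ccc(Cl)cc23)CC1`, has not been measured in this assay. Its difference from compound 2 is 3-cyanophenyl in place of 3,4-dimethylphenyl on a sulfonyl sulfur. Going by the values given here, no measured pair shows a nitrile entering, and no measured pair shows both methyl groups of the 3,4-dimethylphenyl leaving at once; the one relevant step, a number 11 percentage points lower from compound 1 to compound 2 (beyond the scatter), shows that the second methyl cost a modest amount. From the compounds shown here alone, removing it again might give that amount back, while the nitrile is untested, so the direction of the combined change cannot be fixed from the data. A step of no more than modest size in this assay is expected, in either direction, consistent with a number 1 percentage points higher from compound 2 to compound 4 (within the scatter) as the expected change from compound 2.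

Compound 4 is therefore estimated at 85%, with a range from 65% to 97% in this assay.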

Compound 4, a percentage reported as inhibition, at one concentration (the size of the read-out at that concentration, not a potency): 90%
Beside the measured number, compound 4's estimate is 5 percentage points below it; the range from low to high includes it.
By their numbers in this assay, from the lowest: compounds 2, 3, 4 and 1 (each within the scatter of the next, the first and the last beyond it).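

In this assay, a nitrile-bearing ring on the sulfonyl sulfur gives a number 6 percentage points higher from compound 2 to compound 4 (within the scatter) and a number 5 percentage points lower from compound 1 to compound 4 (within the scatter), so neither replacement of a methyl-bearing ring by 3-cyanophenyl gives a step that can be read as a change. For the compounds shown here, until now the only step at this place was a number 11 percentage points lower from compound 1 to compound 2 (beyond the scatter), which involved methyl groups alone; the new pair extends the substituents seen on this ring to a nitrile, and compound 4 cannot be ordered against either compound 1 or compound 2, although those two are separated beyond the scatter. Nothing at hand bears on why these numbers fall as they do.

The compounds shown leave open whether the sulfonyl sulfur would keep such numbers with a ring carrying an amine or a carboxylic acid, or with a longer alkyl chain in place of the ring. Since this assay gives inhibition at one concentration only, these compounds also leave open any difference in potency among compound 1, compound 2 and compound 4.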